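Swapping an aryl for a benzyl group on the amine

The source may hold more compounds than are shown below. What is called first, only, known or untested is meant among the compounds shown, and "the series" means these compounds.

Measured compounds:
- Compound 1, `Cc1ccc(NC2=CC(=O)c3c(nc4n3[C@H]3OC[C@@H](O)[C@H]3OC4)C2=O)cc1`: 6590 nM
- Compound 2, `COc1ccc(NC2=CC(=O)c3nc4n(c3C2=O)[C@H]2OC[C@@H](O)[C@H]2OC4)cc1`: 4780 nM

Both compounds share the same core and were tested in a functional assay on HeLa cells (Homo sapiens) for inhibition, read by sulforhodamine B assay; on this read-out higher numbers stand for weaker inhibition and lower numbers for stronger inhibition. In this assay compound 1 gives 6590 nM, the highest of the two numbers. Its nearest neighbour is compound 2, which gives 4780 nM; the gap between the two numbers lies within the usual scatter, so the two compounds cannot be told apart on these data.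

Compound 3, `O=C1C(NCc2ccccc2)=CC(=O)c2c1nc1n2[C@H]2OC[C@@H](O)[C@H]2OC1`, has not yet been measured. It differs from compound 1 in one place: benzyl in place of 4-methylphenyl on an amine nitrogen. The amine nitrogen keeps its other neighbour, a double-bonded ring carbon, and the same atoms are present, joined differently, so that the aromatic ring is moved one bond further from the nitrogen.

Among the compounds with values here, no measured pair shows this kind of change, so there is no step to lean on. With both measured compounds sitting at weak inhibition and close together, the expectation is a step of a 1.2-fold higher number from compound 1 to compound 3 (0.08 log units; within the scatter) in this assay, most likely not beyond the scatter, with more room for a weaker than for a stronger result. Compound 3 is therefore estimated at 8000 nM, with a range from 2500 nM to 25000 nM.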

Compound 3, half-maximal inhibitory concentration: 11000 nM
Beside the measured number, compound 3's estimate is 1.4-fold (0.14 log units) below it; the range from low to high includes it.
By their numbers in this assay, from the lowest: compounds 2, 1 and 3 (each within the scatter of the next, the first and the last beyond it).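

Benzyl in place of 4-methylphenyl on the amine nitrogen gives a 1.7-fold higher number from compound 1 to compound 3 (0.22 log units; within the scatter) in this assay, so moving the aromatic ring one bond further from the nitrogen produces no change that can be read with confidence. Within the data shown here, this pair is the first to isolate a change at this position, and it shows that this rearrangement of the same atoms neither clearly strengthens nor clearly weakens inhibition. No supporting data explain the size of this step or connect it to a property of either group.

Still open, as far as these compounds go, is whether a clear difference would appear with a longer link between the nitrogen and the ring, as in 2-phenylethyl, or with no aromatic ring at all, as in cyclohexyl. A carboxylic acid or an amine on the benzyl ring would also test whether this position can give a number beyond the scatter of compound 3 in this assay, in either direction.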